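Bromophenyl to Dihydroxyphenyl: Expectation from Three Measured Compounds

The compounds below may be only part of what the source reports. "The series", "measured", "known", "first", "only" and "open" are said of these compounds alone.

The three compounds measured in a functional assay on KB cells (Homo sapiens) for antiproliferative activity, read by sulforhodamine B assay, with a stated time of 3 days (on this read-out lower numbers stand for an effect already at smaller amounts and higher numbers for an effect only at larger amounts of compound), are:

Compound 1, `CCC1=C(O)c2c(oc(-c3ccc(Br)cc3)cc2=O)C(CC)(CC)C1=O`, gives > 48.1 uM, which is a limit of the assay and not a number.
Compound 2, `CCC1=C(O)c2c(oc(-c3ccccc3C(F)(F)F)cc2=O)C(CC)(CC)C1=O`, gives 45.6 uM.
Compound 3, `CCC1=C(O)c2c(oc(-c3cc(Cl)c(OC)c(OC)c3)cc2=O)C(CC)(CC)C1=O`, gives 21.8 uM.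

Compound 1 therefore stands at the limit of > 48.1 uM in this assay, at which 1 of the 3 values shown sits, so for compound 1 only a limit is known and no number. Compound 2 and compound 3 both give numbers, and the gap between them is beyond the usual scatter, with compound 3 showing its effect at smaller amounts. Among the measured compounds shown here, no single-change step between two measured compounds exists in this set, so the size of the move from compound 1 to compound 4 cannot be read from a measured pair.

Compound 4, `CCC1=C(O)c2c(oc(-c3ccc(O)c(O)c3)cc2=O)C(CC)(CC)C1=O`, differs from compound 1 by 3,4-dihydroxyphenyl in place of 4-bromophenyl on an aromatic carbon. The expectation is a step beyond the scatter in this assay toward an effect at smaller amounts, since compound 3, giving 21.8 uM, shows that an oxygen-bearing aryl group at this position can yield a number rather than a limit. Compound 4 is accordingly estimated at 25 uM, with a range from 8 uM to 60 uM. This estimate means a step of an at least 1.9-fold lower number from compound 1 to compound 4 (0.28 log units; that floor lies within the scatter) that is expected to carry compound 4 clear of the limit.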

Compound 4, concentration for half-maximal effect: 10 uM
For compound 4 the middle estimate is 2.5-fold (0.40 log units) above the measured one, and the stated range covers the measured number.
By their numbers in this assay, from the lowest: compound 4; then compound 3; then compound 2. At a limit, above all of these: compound 1.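

In this assay the set now holds its first readable single change, 3,4-dihydroxyphenyl in place of 4-bromophenyl on an aromatic carbon next to the ring oxygen, and it amounts to an at least 4.8-fold lower number from compound 1 to compound 4 (0.68 log units; beyond the scatter). Compound 1 remains a limit and not a number, so this step has a floor and no fixed size: the limit of > 48.1 uM in this assay, at which 1 of the 4 values shown sits. The change shows that, with the rest of the core unchanged, swapping the aryl group at this place alone can move the read-out beyond the usual scatter, and that an aryl group with hydrogen-bond donors, which 4-bromophenyl lacks, is compatible with a measured number here.

This one pair cannot separate the loss of the bromine from the gain of the two hydroxyl groups, nor show whether both hydroxyl groups are needed. The compounds shown also leave open how a phenyl ring carrying a single hydroxyl, an amine or a carboxylic acid would read at this place, and whether the step would hold on the same core.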